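Methyl added to the piperidine amide of compound 1

The source may report more compounds than this note shows. Statements on the series, on what has been measured and on what is new or still open speak of the compounds shown alone.

Compound 1 `CS(=O)(=O)c1ccc(C(=O)NCCC(=O)N2CCCCC2)cc1[N+](=O)[O-]` is the parent of this small set. In an assay on isolated protein for inhibition of vitamin D3 receptor (Homo sapiens), read by fluorescence polarization (on this read-out higher numbers stand for weaker inhibition and lower numbers for stronger inhibition), compound 1 gives > 60000 nM, which is a limit of the assay and not a number. Compound 2 `CN(Cc1ccccc1F)C(=O)CNC(=O)c1ccc(S(C)(=O)=O)c([N+](=O)[O-])c1` carries a different amide end on the shared core. In this assay compound 2 gives > 60000 nM, again a limit. Compound 3 `CC(C)N(C(=O)CNC(=O)c1ccc(S(C)(=O)=O)c([N+](=O)[O-])c1)C(C)C` is the third variation of the amide end. In this assay compound 3 gives > 60000 nM, also a limit. For the measured compounds named here, all three values rest at the same point, (the limit of > 60000 nM in this assay, at which 3 of the 3 values shown sit), so no step between measured compounds can be read, and compound 1 stands level with the other two: its value is a limit like theirs.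

Compound 4 `CC1CCN(C(=O)CCNC(=O)c2ccc(S(C)(=O)=O)c([N+](=O)[O-])c2)CC1` differs from compound 1 in one place: methyl in place of hydrogen on a saturated ring carbon. Going by the values given here, with every measured value a limit, no measured step shows what such a change does. The expected step from compound 1 to compound 4 in this assay is a step that the limit leaves unreadable from compound 1 to compound 4, none beyond the scatter. The estimate for compound 4 in this assay is 90000 nM, with a range from 30000 nM to 300000 nM, and the result is expected most likely to be reported again as a limit.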

Compound 4, half-maximal inhibitory concentration: > 60000 nM
Compound 4 ended at the assay's limit (the forecaster's own chance of this, stated with the estimate: 90%); the middle value lies beyond the limit too.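

Compound 1 and compound 4 both stand at a limit of the assay and not at a number, so no step can be read for piperidin-1-yl to 4-methylpiperidin-1-yl: the limit of > 60000 nM in this assay, at which 4 of the 4 values shown sit. The compounds shown leave open whether this methyl, or any of the amide ends, shifts inhibition at all, and which change to the shared core would give a readable value.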